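The source may report more compounds than this note shows. Statements on the series, on what has been measured and on what is new or still open speak of the compounds shown alone.

Working notes on the series. Compound 1 `CCC1(CCCCN2CCN(c3ccc(F)cc3)CC2)C(=O)Nc2ccccc21` carries the shared core with a chain out to a fluorophenyl-bearing group; in a functional assay on the whole organism (strain Wistar) with Rattus norvegicus as the target, with a stated time of 5 min (a lower number here means that less compound is needed, a higher number that more compound is needed for the effect), compound 1 gives 10 mg/kg. Among the measured compounds shown here, that is the only single number in the set, so compound 1 stands alone as the reference point. Compound 2 `CCC1(CCCCN2CCC(C)CC2)C(=O)Nc2ccccc21` has no result in this assay; its entry reads "not determined" (no result reported). Compound 3 `O=C1Nc2ccc(F)cc2C1CCCCN1CCN(c2ccc(F)cc2)CC1` is reported in this assay only as a limit, > 10 mg/kg, which marks a threshold rather than a measured dose (the limit of > 10 mg/kg in this assay, at which 1 of the 3 values shown sits). For the measured compounds named here, no two measured compounds differ in a single place, so no measured step is available to scale any change.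

Compound 4 `CCC1(CCCCN2CCN(c3ccc(F)c(Cl)c3)CC2)C(=O)Nc2ccccc21` is the unmeasured entry. It differs from compound 1 by chloro in place of hydrogen on an aromatic carbon, ortho to a fluoro group, turning 4-fluorophenyl into 3-chloro-4-fluorophenyl. Going by the values given here, with no measured step to lean on, the expected step in this assay is no change at the digits printed from compound 1 to compound 4 (within the scatter), that is, no change beyond the usual scatter. Compound 4 is therefore estimated at 10 mg/kg, with a range of 3 mg/kg to 30 mg/kg, and a real chance that only a limit is returned.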

Compound 4, minimum effective dose: > 20 mg/kg
Compound 4: only a limit was reported; the forecaster's own chance of this, stated with the estimate: 30%; at least 2.0-fold (0.30 log units) between middle value and limit.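

Compound 4 is known in this assay only through a limit, not a number: the limit of > 20 mg/kg in this assay, at which 1 of the 4 values shown sits. Chloro in place of hydrogen on an aromatic carbon, ortho to a fluoro group, is the first single-place change that can be read in the series, and it reads as an at least 2.0-fold higher number from compound 1 to compound 4 (0.30 log units; that floor lies within the scatter). The 3-chloro-4-fluorophenyl group thus gives no sign of lowering the dose needed relative to the 4-fluorophenyl group, but the floor alone does not establish a rise beyond the scatter.

On these data alone, how far the true dose of compound 4 lies past its limit remains open. As far as these compounds go, whether this result is specific to chloro also remains open, and a methyl or methoxy group at the same place would help to answer that.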